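A Third Ring Swap in a Level Cytotoxicity Series

The source may report more compounds than this note shows. Statements on the series, on what has been measured and on what is new or still open speak of the compounds shown alone.

In a functional assay on HEK-293T cells (Homo sapiens) for cytotoxicity, read by MTT assay (on this read-out higher numbers stand for lower toxicity in this test and lower numbers for higher toxicity in this test), compound 1 `COc1ccc(-c2nc3cnccn3c2Nc2cc(OC)c(OC)c(OC)c2)cc1O` gives 38000 nM, compound 2 `COc1ccc(-c2nc3cnccn3c2Nc2cc(OC)c(OC)c(OC)c2)cc1` gives 54000 nM and compound 3 `COc1cc(Nc2c(-c3ccc(F)cc3)nc3cnccn23)cc(OC)c1OC` gives 36000 nM. These numbers lie within the usual scatter of one another, so compound 3 stands level with the other two. Compound 4 `COc1cc(-c2nc3cnccn3c2Nc2cc(OC)c(OC)c(OC)c2)cc(OC)c1O` carries 4-hydroxy-3,5-dimethoxyphenyl in place of the 4-fluorophenyl of compound 3: 4-hydroxy-3,5-dimethoxyphenyl in place of 4-fluorophenyl on an aromatic carbon. Changes to this same group have so far moved this assay very little: a 1.1-fold lower number from compound 1 to compound 3 (0.02 log units; within the scatter), a 1.5-fold lower number from compound 2 to compound 3 (0.18 log units; within the scatter) and a 1.4-fold higher number from compound 1 to compound 2 (0.15 log units; within the scatter), each within the scatter. No step beyond the scatter is therefore expected, and the estimated step is a 1.1-fold higher number from compound 3 to compound 4 (0.05 log units; within the scatter). For compound 4 the estimated value is 40000 nM, with an expected range from 20000 nM to 80000 nM.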

Compound 4, concentration lethal to 50% of the cells: 34000 nM
Compound 4: middle estimate off by 1.2-fold (0.07 log units), on the high side; measured number inside the range.
By their numbers in this assay, from the lowest: compounds 4, 3, 1 and 2 (each within the scatter of the next).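

In this assay the swap at this position to the bulkier 4-hydroxy-3,5-dimethoxyphenyl, which brings a hydrogen-bond donor that 4-fluorophenyl lacks, leaves the number level (a 1.1-fold lower number from compound 3 to compound 4 (0.02 log units; within the scatter)). The steps from the two other aryl groups also stay within the scatter (a 1.6-fold lower number from compound 2 to compound 4 (0.20 log units; within the scatter); a 1.1-fold lower number from compound 1 to compound 4 (0.05 log units; within the scatter)). All four phenyl groups shown here, from the singly substituted to the triply substituted, therefore give numbers that cannot be told apart.

No measurement here explains this flatness. From the compounds shown here alone, whether an amine or a carboxylic acid at this position would shift the number remains open.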